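The compounds below may be only part of what the source reports. "The series", "measured", "known", "first", "only" and "open" are said of these compounds alone.

Working notes on the series. The shared core carries a piperidine-linked thiourea bearing an aryl group on the amide-type nitrogen; in a functional assay on the whole organism (strain Swiss albino) with Mus musculus as the target, with a stated time of 4 h (on this read-out higher numbers stand for an effect only at larger amounts of compound and lower numbers for an effect already at smaller amounts), compound 1 `COc1cc2c(cc1OC)C(=O)C(CC1CCN(C(=S)Nc3ccccc3)CC1)C2` gives 300 mg/kg. Compound 2 `COc1cc2c(cc1OC)C(=O)C(CC1CCN(C(=S)Nc3cccc([N+](=O)[O-])c3)CC1)C2` has been run in this assay, yet compound 2 gives "not determined" (no result reported), so no number stands for it and nothing can be said of where it lies against compound 1. The next member, compound 3 `COc1cc2c(cc1OC)C(=O)C(CC1CCN(C(=S)Nc3ccccc3Cl)CC1)C2`, differs from compound 2 in one place: 2-chlorophenyl in place of 3-nitrophenyl on an amide-type nitrogen. Going by the values given here, no step between two measured compounds is available for this change, so no size or direction can be read off for it; the only anchor for the series is the value of compound 1 in this assay, 300 mg/kg. The step from compound 2 to compound 3 is therefore taken as undetermined, with no expectation of movement beyond the usual scatter in either direction. On that basis compound 3 is estimated at 300 mg/kg in this assay, within a range from 100 mg/kg to 1000 mg/kg.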

Compound 3, minimum effective dose: 300 mg/kg
Estimate against measurement, compound 3: no gap at the digits printed; the measured number falls inside the stated range.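

In this assay, the aryl group on the amide-type nitrogen now has its first readable step, no change at the digits printed from compound 1 to compound 3 (within the scatter), so this position accepts chloro in place of hydrogen on an aromatic carbon without a measurable shift in minimum effective dose. This holds for 2-chlorophenyl against plain phenyl only, and steps involving compound 2 cannot be read, as it carries no number. Nothing available explains this result.

As far as these compounds go, the effect of 3-nitrophenyl at this position therefore remains unknown, and a single chloro step cannot show how far the tolerance extends. Also open, from the compounds shown here alone, is whether a carboxylic acid or an amine on the phenyl ring, or a longer alkyl chain in place of the ring on the amide-type nitrogen, would change the dose.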